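Methoxy in place of hydrogen on a shared core

The compounds below may be only part of what the source reports. "The series", "measured", "known", "first", "only" and "open" are said of these compounds alone.

All values here come from a physicochemical assay for lipophilicity, at pH 7.4; a lower number here means a more polar compound, a higher number a more lipophilic compound.

compound 1: `Cc1[nH]c2ccccc2c(=O)c1Cc1ccccc1` — 1.93
compound 2: `Cc1[nH]c2ccccc2c(=O)c1Br` — 1.67
compound 3: `COc1ccc2[nH]c(C)c(Br)c(=O)c2c1` — 1.62

Compound 2 and compound 3 differ in one place only, (methoxy in place of hydrogen on an aromatic carbon). The step in this assay is a number 0.05 log units lower from compound 2 to compound 3 (within the scatter), so within this pair the methoxy group leaves the read-out essentially unchanged.

Compound 1 and compound 2 share a core but differ by more than one change; the difference between the two cores is not broken down here. Their values in this assay lie within the scatter of each other, so no order between them is claimed. Compound 1 stands above compound 3 by a margin beyond the scatter, and it carries the highest of the three numbers, though its gap to compound 2 is within the scatter.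

Compound 4, `COc1ccc2c(=O)c(Cc3ccccc3)c(C)[nH]c2c1`, has not yet been measured. It is related to compound 1 by methoxy in place of hydrogen on an aromatic carbon. This is the same change as that from compound 2 to compound 3, made on the same place of the same ring system, only on the core of compound 1 instead of the core of compound 2.

The step from compound 1 to compound 4 in this assay is therefore expected to be small, a number 0.05 log units lower from compound 1 to compound 4 (within the scatter), beside the earlier a number 0.05 log units lower from compound 2 to compound 3 (within the scatter); the expectation rests on that single measured pair. For compound 4 the expected value in this assay is 1.88, with a range from 1.6 to 2.15.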

Compound 4, distribution coefficient: 2.52
For compound 4 the middle estimate is 0.64 log units below the measured one, and the stated range ends below it.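

In this assay the methoxy in place of hydrogen gives a number 0.59 log units higher from compound 1 to compound 4 (beyond the scatter) on the core of compound 1, against a number 0.05 log units lower from compound 2 to compound 3 (within the scatter) on the core of compound 2, so the same change on the same aromatic carbon does not carry over at the same size between these two cores. The first step is beyond the scatter and the second within it, but two pairs give no rule for any further core, and the cores differ by more than one change, so the part of the core that goes with the larger step cannot be identified. No measurement at hand accounts for the contrast between the two steps.

The compounds shown leave open how other groups in place of hydrogen at this aromatic carbon, such as an amine, a carboxylic acid or a longer alkoxy chain, would read on each of the two cores. Also open, from the compounds shown here alone, is whether methoxy on another carbon of the same aromatic ring would follow the small step seen on the core of compound 2 or the larger one seen on the core of compound 1.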